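The source may report more compounds than this note shows. Statements on the series, on what has been measured and on what is new or still open speak of the compounds shown alone.

Measured compounds:
- compound 1, `NC1=NC2(CCSCC2)N(OCCCOc2ccc(Br)cc2)C(N)=N1`: 440 nM
- compound 2, `NC1=NC2(CCOCC2)N(OCCCOc2ccc(Cl)cc2Cl)C(N)=N1`: "not determined" (no result reported)
- compound 3, `CC(C)(C)c1ccc(OCCCON2C(N)=NC(N)=NC23CCOCC3)cc1`: "not determined" (no result reported)

Three compounds of this series were made, but only one of them comes with a number. In a functional assay on MDA-MB-231 cells (Homo sapiens) for antiproliferative activity, read by MTT assay, with a stated time of 72 h (a lower number here means a stronger inhibitor, a higher number a weaker inhibitor), compound 1 gives 440 nM. For the measured compounds named here, for compound 2 and compound 3 no result was reported in this assay, so compound 1 stands alone, and no comparison between measured compounds is possible; nothing can be said yet about how changes on the shared core or on the aromatic ring affect potency.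

The next compound, compound 4, `NC1=NC2(CCSCC2)N(OCCCOc2ccc(Cl)c(Cl)c2)C(N)=N1`, keeps the core of compound 1 and changes only the aromatic group at the end of the chain: 3,4-dichlorophenyl in place of 4-bromophenyl on an oxygen on a saturated carbon. Going by the values given here, with no measured pair to lean on, the size of the step is a guess; a swap of one halogenated phenyl for another is expected to move the number little, and any change is expected to stay near the scatter of this assay. The step from compound 1 to compound 4 is expected to be a 1.3-fold lower number from compound 1 to compound 4 (0.10 log units; within the scatter). Compound 4 is therefore estimated at 350 nM, within a range from 150 nM to 1000 nM.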

Compound 4, half-maximal inhibitory concentration: 10 nM
Beside the measured number, compound 4's estimate is 35-fold (1.54 log units) above it; measured number below the stated range.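

In this assay the shared core stays fixed while 3,4-dichlorophenyl takes the place of 4-bromophenyl, and the result is a 44-fold lower number from compound 1 to compound 4 (1.64 log units; beyond the scatter) with no other part of the structure touched. For the compounds shown here, the single number for compound 1 could not show this: the aromatic group at the end of the chain is a place where one swap of halogenated phenyl groups can shift potency far beyond the usual scatter. Nothing among the data given explains why this swap has so large an effect.

The compounds shown leave open whether both chlorine atoms are needed, which a 3-chlorophenyl, a 4-chlorophenyl or a plain phenyl group at this position would help to separate. Also open, from the compounds shown here alone, is whether the gain survives a longer chain between the oxygen atoms or a different core.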